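A few compounds are considered here, and "the series" means these few. Any claim that something is new, unique, unknown or untested is made for them only; others in the source may bear on it.

Measured so far:
compound 1 `COc1ccc(CCCc2ccc(OC)cc2OC)c(O)c1` – 100%
compound 2 `COc1ccc(/C=C/C(=O)c2ccc(OC)c(OC)c2)cc1` – 97.2%
compound 3 `COc1ccc(C(=O)CCc2ccc(OC)c(OC)c2OC)c(O)c1` – 101%

Three compounds have been examined in an ADME assay on RAW264.7 cells (Mus musculus) for cytotoxicity, read by MTT assay, with a stated time of 24 h, tested at 1.25 ug/mL; a lower number here means a stronger effect, a higher number a weaker effect of the compound at the concentration tested. Compound 1 gives 100%, compound 2 gives 97.2% and compound 3 gives 101%. Compound 2 holds the smallest of the three numbers, but the gap to compound 1 and the gap to compound 3 both fall within the usual scatter of this assay, so the three compounds cannot be told apart: each leaves the cells essentially as viable as untreated ones at this concentration.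

Compound 4 `COc1ccc(/C=C/C(=O)c2ccc(OC)c(OC)c2)cc1O` has not yet been measured. It differs from compound 2 in one place: hydroxy in place of hydrogen on an aromatic carbon.

Within the data shown here, no step between two measured compounds is available to calibrate the effect of such a change. Since every measured number sits close to full viability and the change is a single small group, no step beyond the scatter is expected in this assay. Compound 4 is expected to give 98%, somewhere between 90% and 105%, which means an expected step of a number 0.8 percentage points higher from compound 2 to compound 4 (within the scatter) of no consequence.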

Compound 4, a percentage reported as activity, at one concentration (the size of the read-out at that concentration, not a potency): 91.4%
Beside the measured number, compound 4's estimate is 6.6 percentage points above it; the range from low to high includes it.
By their numbers in this assay, from the lowest: compounds 4, 2, 1 and 3 (each within the scatter of the next).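

Hydroxy in place of hydrogen on an aromatic carbon, ortho to a methoxy group and meta to a large group, gives a number 5.8 percentage points lower from compound 2 to compound 4 (within the scatter) in this assay. Among these compounds, this is the first step between two compounds that differ in one place, and it shows that this change at this position does not separate compound 4 from compound 2 at the concentration tested. No independent measurement bears on this result.

As far as these compounds go, it remains open whether an amine or a carboxylic acid on the same aromatic carbon would also stay within the scatter of compound 2. The compounds shown also leave open whether compound 2 and compound 4 would still be indistinguishable at a higher concentration.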